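Compound 1 to compound 4: a 4-cyanophenoxy swap

The source may report more compounds than this note shows. Statements on the series, on what has been measured and on what is new or still open speak of the compounds shown alone.

In a functional assay on LNCaP cells (Homo sapiens) for antiproliferative activity, read by propidium iodide staining, with a stated time of 96 h (a higher number here means a weaker inhibitor, a lower number a stronger inhibitor), compound 1 `CC(O)(CSc1ccc(F)cc1)C(=O)Nc1cccc(S(F)(F)(F)(F)F)c1` gives 26900 nM at the top of the three numbers, compound 2 `CC(O)(CSc1ccc(C(F)(F)F)cc1)C(=O)Nc1cccc(S(F)(F)(F)(F)F)c1` gives 17500 nM and compound 3 `CC(O)(CSc1ccc(OC(F)(F)F)cc1)C(=O)Nc1cccc(S(F)(F)(F)(F)F)c1` gives 10300 nM in the same read-out. Only compound 3 stands clearly apart from compound 1. The change to compound 4 `CC(O)(COc1ccc(C#N)cc1)C(=O)Nc1cccc(S(F)(F)(F)(F)F)c1` is 4-cyanophenoxy in place of (4-fluorophenyl)sulfanyl on a saturated chain carbon, two bonds along the chain from a carbonyl carbon and an oxygen on a saturated carbon on a saturated chain carbon, two bonds along the chain from a carbonyl carbon and an oxygen on a saturated carbon. Of the measured steps, a 1.5-fold lower number from compound 1 to compound 2 (0.19 log units; within the scatter) and a 1.7-fold lower number from compound 2 to compound 3 (0.23 log units; within the scatter) are small, and a 2.6-fold lower number from compound 1 to compound 3 (0.42 log units; beyond the scatter) is modest. All three keep the sulfanyl link, so they bear on the swap only in part. The expected change in this assay is a 1.5-fold lower number from compound 1 to compound 4 (0.17 log units; within the scatter) and no clear shift in either direction is expected. Compound 4 is estimated at 18000 nM (expected range 7000 nM to 45000 nM).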

Compound 4, half-maximal inhibitory concentration: 30000 nM
For compound 4 the middle estimate is 1.7-fold (0.22 log units) below the measured one; the range from low to high includes it.
By their numbers in this assay, from the lowest: compounds 3, 2, 1 and 4 (each within the scatter of the next, the first and the last beyond it).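

Going by these compounds alone, the first change of the link itself, 4-cyanophenoxy in place of (4-fluorophenyl)sulfanyl, leaves compound 4 indistinguishable from compound 1 in this assay (a 1.1-fold higher number from compound 1 to compound 4 (0.05 log units; within the scatter)). At this position, the sulfanyl link is therefore not needed to keep a number of this size, at least when the nitrile comes with the oxygen link. The link and the ring substituent change together, so their separate contributions cannot be told apart. No measurement available here explains the result.

A 4-fluorophenoxy group would separate the two changes. On these data alone, whether an amine or a carboxylic acid in place of the nitrile would shift the number remains open.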